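The source may report more compounds than this note shows. Statements on the series, on what has been measured and on what is new or still open speak of the compounds shown alone.

Of the compounds shown here, three built on one shared core have been tested in a functional assay on MCF7 cells (Homo sapiens) for cytotoxicity, read by MTT assay, with a stated time of 72 h, tested at 3 uM; a lower number here means less inhibition of growth, a higher number more inhibition of growth at the concentration tested. Compound 1, `Cc1cccc(/C(N)=N/NC(=S)N2CCSCC2)n1`, gives 20.6% in this assay. Compound 2, `N/C(=N\NC(=S)N1CCSCC1)c1ccccn1`, gives 29%. Compound 3, `N/C(=N\NC(=S)N1CCCCC1)c1ccccn1`, gives 38.6%; its gap from compound 2 stays within the scatter, while the values of compound 3 and compound 1 lie further apart than the scatter.

Compound 2 and compound 1 differ in one place: methyl in place of hydrogen on an aromatic carbon. This change gave a number 8.4 percentage points lower from compound 2 to compound 1 (within the scatter). Compound 2 and compound 3 differ in their cores: piperidin-1-yl in place of thiomorpholin-4-yl on a thiocarbonyl carbon. That change gave a number 9.6 percentage points higher from compound 2 to compound 3 (within the scatter).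

Compound 4, `Cc1ccnc(/C(N)=N/NC(=S)N2CCCCC2)c1`, has not yet been measured. It differs from compound 3 in one place: methyl in place of hydrogen on an aromatic carbon. Among the compounds with values here, this is the same kind of change as the one from compound 2 to compound 1, but not the same change: in compound 1 the methyl sits next to the ring nitrogen, in compound 4 it sits opposite the ring nitrogen; in both it is meta to a large group. Among the compounds here this kind of change occurs twice, measured once.

The expected step is a number 6.6 percentage points lower from compound 3 to compound 4 (within the scatter), a small one, because a number 8.4 percentage points lower from compound 2 to compound 1 (within the scatter) stayed within the scatter. That rests on a single measured example, and the different place of the methyl adds uncertainty.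

Compound 4 is estimated to give 32% in this assay, expected between 20% and 44%.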

Compound 4, percent growth inhibition at one concentration: 29.4%
Compound 4: middle estimate off by 2.6 percentage points, on the high side; low and high end bracket the measured number.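

In this assay, methyl in place of hydrogen on an aromatic carbon gave a number 9.2 percentage points lower from compound 3 to compound 4 (within the scatter), and this step closely matches the one seen on the other core: the same change on two cores in this assay, a number 8.4 percentage points lower (within the scatter) from compound 2 to compound 1 and a number 9.2 percentage points lower (within the scatter) from compound 3 to compound 4, 0.8 percentage points apart, within the scatter of two such steps On these two cores, then, the change carries over at about the same size, although each step on its own stays within the scatter, so neither one establishes that the methyl makes a real difference to growth inhibition. The agreement also does not show that the methyl's place on the ring is unimportant, since it sits opposite the ring nitrogen in compound 4 and at a different place in compound 1, and two cores are too few to speak for the whole series.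

The compounds shown leave open whether a group larger than methyl on the same ring, such as ethyl, methoxy or a chlorine atom, would give a step beyond the scatter. They also leave open how a methyl at each of the other ring places would compare on a single core, and what a morpholin-4-yl group on the thiocarbonyl carbon would give.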